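The compounds below may be only part of what the source reports. "The series", "measured", "known", "first", "only" and "open" are said of these compounds alone.

Compound 1, `CC(C)c1nn(-c2ccc(C(N)=O)c(N[C@H]3CC[C@H](O)CC3)c2)c2nccc(-n3cnc(-c4ccc(Oc5ccccc5)cc4)c3)c12`, is the anchor of this short series. In a functional assay on SK-BR-3 cells (Homo sapiens) for inhibition, read by CellTiter-Glo, with a stated time of 72 h (on this read-out lower numbers stand for stronger inhibition and higher numbers for weaker inhibition), compound 1 gives 503 nM, the lowest of the two numbers that are actually reported. Compound 2, `CC(C)c1nn(-c2ccc(C(N)=O)cc2)c2nccc(-n3cnc(-c4cnn(C)c4)c3)c12`, which carries a smaller ring on the imidazole and lacks the hydroxycyclohexylamino group, gives 1640 nM in this assay, a higher value that lies beyond the usual scatter. Compound 3, `CC(C)c1nn(-c2ccc(C(N)=O)c(N[C@H]3CC[C@H](O)CC3)c2)c2nccc(-c3ccc4ccccc4c3)c12`, is reported only as a limit in this assay, > 10000 nM; this is the limit of > 10000 nM in this assay, at which 1 of the 3 values shown sits, so no number is known for it.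

Compound 4, `COc1ccc(-c2cn(-c3ccnc4c3c(C(C)C)nn4-c3ccc(C(N)=O)c(N[C@H]4CC[C@H](O)CC4)c3)cn2)cc1`, differs from compound 1 in a single place: methyl in place of phenyl on an oxygen on an aromatic ring, so the phenoxy group becomes a methoxy group. Within the data shown here, no measured pair in the set shows this particular swap, so there is no step to lean on. Compound 2 shows that a smaller group at the far end of this arm can go with weaker inhibition, and compound 4 is therefore expected to land somewhat weaker than compound 1, with the estimated step from compound 1 to compound 4 being a 2.4-fold higher number from compound 1 to compound 4 (0.38 log units; beyond the scatter). For compound 4 the expected value in this assay is 1200 nM, within a range of 400 nM to 4000 nM.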

Compound 4, half-maximal inhibitory concentration: 256 nM
Compound 4: the middle estimate sits 4.7-fold (0.67 log units) above what was measured; the whole stated range lies above it.
By their numbers in this assay, from the lowest: compounds 4 and 1 (each within the scatter of the next); then compound 2. At a limit, above all of these: compound 3.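

In this assay the change from phenoxy to methoxy gives a 2.0-fold lower number from compound 1 to compound 4 (0.29 log units; within the scatter), so the two compounds cannot be told apart on this read-out. Among these compounds, this is the first direct look at this position, and it shows that the whole outer phenyl ring, with its 6 heavy atoms, can give way to a single methyl carbon with no change beyond the scatter. None of the measurements shown helps to explain why the two groups read alike.

A single swap at one position still says little about how much this position tolerates in general. Open questions are how a free hydroxyl, an ethyl group or a longer chain on the oxygen would read here, and what an amine in place of the oxygen would do.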